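The source may hold more compounds than are shown below. What is called first, only, known or untested is meant among the compounds shown, and "the series" means these compounds.

Working notes on the amide series.

Three compounds sharing one core have been run in a functional assay on BXPC-3 cells (Homo sapiens) for antiproliferative activity, read by MTT assay, with a stated time of 24 h; a lower number here means a stronger inhibitor, a higher number a weaker inhibitor. Compound 1 `CCn1c(C(=O)NC(C)(C)CO)ccc1C(CC)(CC)c1ccc(OCS(=O)(=O)c2ccccc2)c(C)c1` gives 18300 nM. Compound 2 `CCn1c(C(=O)NC2(CO)CC2)ccc1C(CC)(CC)c1ccc(OCS(=O)(=O)c2ccccc2)c(C)c1` gives 45400 nM, and compound 3 `CCn1c(C(=O)NCCCO)ccc1C(CC)(CC)c1ccc(OCS(=O)(=O)c2ccccc2)c(C)c1` gives 26600 nM. Compound 1 holds the lowest of the three numbers; the step of a 1.5-fold higher number from compound 1 to compound 3 (0.16 log units; within the scatter) is within the scatter, while the step of a 2.5-fold higher number from compound 1 to compound 2 (0.39 log units; beyond the scatter) is modest but beyond it. Between the other two, a 1.7-fold lower number from compound 2 to compound 3 (0.23 log units; within the scatter) is within the scatter. All three numbers sit high, so the whole set is weak in this assay.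

Compound 4 `CCn1c(C(=O)N[C@H](CC(=O)O)C(=O)O)ccc1C(CC)(CC)c1ccc(OCS(=O)(=O)c2ccccc2)c(C)c1` is the next member, not yet measured. It differs from compound 1 as follows: 1,2-dicarboxyethyl in place of 1-(hydroxymethyl)-1-methylethyl on an amide-type nitrogen. Among the compounds with values here, the steps that bear on this change are the two that also replace the group on the amide-type nitrogen of compound 1, namely a 2.5-fold higher number from compound 1 to compound 2 (0.39 log units; beyond the scatter) and a 1.5-fold higher number from compound 1 to compound 3 (0.16 log units; within the scatter); neither moved the number much, and neither lowered it. Within the data shown here, on that basis the expectation for compound 4 is a small rise in the number, of about the size seen for compound 2, or no step beyond the scatter, because the only bearing step beyond the scatter is a 2.5-fold higher number from compound 1 to compound 2 (0.39 log units; beyond the scatter). The step expected is a 1.6-fold higher number from compound 1 to compound 4 (0.21 log units; within the scatter). The estimate for compound 4 is therefore 30000 nM, with a range from 12000 nM to 80000 nM.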

Compound 4, half-maximal inhibitory concentration: > 50000 nM
Compound 4: no number, only a limit (the forecaster's own chance of this, stated with the estimate: 15%); at least 1.6-fold (0.22 log units) between middle value and limit.
By their numbers in this assay, from the lowest: compounds 1, 3 and 2 (each within the scatter of the next, the first and the last beyond it). At a limit, above all of these: compound 4.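

Compound 4 gives no number, only a limit: the limit of > 50000 nM in this assay, at which 1 of the 4 values shown sits. Even at its floor, the change to 1,2-dicarboxyethyl on the amide-type nitrogen gives an at least 2.7-fold higher number from compound 1 to compound 4 (0.43 log units; beyond the scatter), so this position does not accept every replacement of the group in compound 1 without a step beyond the scatter, and the new group does not lower the number. The comparisons with the other two amides are less firm: an at least 1.8-fold higher number from compound 3 to compound 4 (0.27 log units; that floor lies within the scatter) and an at least 1.1-fold higher number from compound 2 to compound 4 (0.04 log units; that floor lies within the scatter) have floors within the scatter, so these data do not establish a separation in either case, although the limit leaves room for larger steps.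

Going by these compounds, it remains open whether a single carboxylic acid, a methyl ester of 1,2-dicarboxyethyl or an amine on this nitrogen would behave as 1,2-dicarboxyethyl does, and what the opposite configuration at its defined stereocentre would give. No group shown on the amide-type nitrogen lowers the number from compound 1, so whether any replacement there can do so is also unresolved.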